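This account rests on a few compounds, and the source may have more. Where it says the series, first, only, none or still open, it means among the compounds named here.

Two compounds share one core and differ only in the group on the carbonyl carbon attached to the ring nitrogen. Compound 1 `Cc1nc(S(C)(=O)=O)ccc1Oc1ncnc(OC2CCN(C(=O)OC3(C(F)(F)F)CCC3)CC2)c1F` gives in a functional assay on isolated protein for inhibition of Glucose-dependent insulinotropic receptor (Rattus norvegicus), read by HTRF and cAMP accumulation (on this read-out lower numbers stand for smaller maximal responses and higher numbers for larger maximal responses), a value of 82%, and compound 2 `Cc1nc(S(C)(=O)=O)ccc1Oc1ncnc(OC2CCN(C(=O)SC3CCC3)CC2)c1F` gives in this assay a value of 81%. For the measured compounds named here, the one measured step, a number 1 percentage points lower from compound 1 to compound 2 (within the scatter), stays within the scatter. Going by the values given here, on these numbers compound 2 stands level with its single neighbour, no order between the two being readable.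

Compound 3 `Cc1nc(S(C)(=O)=O)ccc1Oc1ncnc(OC2CCN(C(=O)c3ncc(Cl)cn3)CC2)c1F` is not yet measured. It differs from compound 2 in one place: 5-chloropyrimidin-2-yl in place of cyclobutylsulfanyl on a carbonyl carbon. Among the compounds with values here, only one measured step bears on this change, the earlier exchange on the same carbonyl carbon, and that step was within the scatter. With nothing in the data pointing either way, no step beyond the scatter is expected for compound 3, so a number 1 percentage points lower from compound 2 to compound 3 (within the scatter) is estimated as small. Compound 3 is therefore expected to give in this assay about 80%, between 65% and 92%.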

Compound 3, largest response reached (reported as efficacy), in percent of the reference or control that the assay uses: 77%
For compound 3 the middle estimate is 3 percentage points above the measured one, within the range that was stated.
By their numbers in this assay, from the lowest: compounds 3, 2 and 1 (each within the scatter of the next).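

In this assay, for the compounds shown here, the carbonyl carbon carries a six-membered aromatic ring with 2 hetero atoms in compound 3, where the earlier compounds had a four-membered non-aromatic ring of carbon only, and the result is a number 4 percentage points lower from compound 2 to compound 3 (within the scatter) and a number 5 percentage points lower from compound 1 to compound 3 (within the scatter) as well. This position therefore accepts three quite different groups with no order readable among them, and an aromatic ring on the carbonyl carbon is as compatible with a large maximal response as the non-aromatic ones. (Nothing measured here gives a reason for this).

Still open, going by these compounds, is whether any group at this place gives a step beyond the scatter, such as a dimethylamino group, a carboxylic acid or a longer chain like n-hexyl. Also open, on these data alone, is what the chlorine of 5-chloropyrimidin-2-yl contributes, which only a comparison with plain pyrimidin-2-yl could tell.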